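Notes on a para-pentafluorosulfanyl anilide series in LNCaP cells

The source may report more compounds than this note shows. Statements on the series, on what has been measured and on what is new or still open speak of the compounds shown alone.

Measured compounds:
compound 1, `CC(O)(CSc1cccc(C(F)(F)F)c1)C(=O)Nc1ccc(S(F)(F)(F)(F)F)cc1`: 18300 nM
compound 2, `CC(O)(CSc1cc(C(F)(F)F)cc(C(F)(F)F)c1)C(=O)Nc1ccc(S(F)(F)(F)(F)F)cc1`: 17600 nM
compound 3, `CC(O)(COc1ccc(C#N)cc1)C(=O)Nc1ccc(S(F)(F)(F)(F)F)cc1`: 100000 nM

All three share the anilide core carrying the pentafluorosulfanyl group; they differ in the aryl ether or thioether arm. In a functional assay on LNCaP cells (Homo sapiens) for antiproliferative activity, read by propidium iodide staining, with a stated time of 96 h (a lower number here means a stronger inhibitor, a higher number a weaker inhibitor), compound 1 and compound 2 are separated by one change, (trifluoromethyl in place of hydrogen on an aromatic carbon), and the step is a 1.0-fold lower number from compound 1 to compound 2 (0.02 log units; within the scatter). Compound 3 is the weakest of the three: in this assay compound 3 gives 100000 nM, compound 1 gives 18300 nM and compound 2 gives 17600 nM, and the gap from compound 3 to each of the other two lies beyond the scatter. How the core of compound 3 differs from the core of compound 1 is not broken down here.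

Compound 4, `CC(O)(COc1ccc(C#N)cc1C(F)(F)F)C(=O)Nc1ccc(S(F)(F)(F)(F)F)cc1`, has not been measured. It differs from compound 3 by trifluoromethyl in place of hydrogen on an aromatic carbon. This is the same kind of change as that from compound 1 to compound 2, but the surroundings differ: in the earlier pair the entering group is meta to a large group and meta to a trifluoromethyl group, whereas here it is ortho to a large group and meta to a cyano group. Since the earlier step of a 1.0-fold lower number from compound 1 to compound 2 (0.02 log units; within the scatter) lay within the scatter, the step from compound 3 to compound 4 is expected to be small as well, a 1.2-fold lower number from compound 3 to compound 4 (0.07 log units; within the scatter), while the different placement leaves the direction uncertain. Compound 4 is therefore estimated at 85000 nM in this assay, within 35000 nM to 200000 nM.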

Compound 4, half-maximal inhibitory concentration: 100000 nM
Estimate against measurement, compound 4: 1.2-fold (0.07 log units) below; the measured number falls inside the stated range.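

In this assay the new step reads no change at the digits printed from compound 3 to compound 4 (within the scatter), so trifluoromethyl in place of hydrogen on an aromatic carbon gives a step within the scatter on the core of compound 3, as it does on the core of compound 1, and the two steps agree: the same change on two cores in this assay, a 1.0-fold lower number (0.02 log units; within the scatter) from compound 1 to compound 2 and no change at the digits printed (within the scatter) from compound 3 to compound 4, 1.0-fold (0.02 log units) apart, within the scatter of two such steps

In these two pairs the change therefore carries from one core to the other as a step within the scatter, including on compound 4, where the entering group is ortho to a large group and meta to a cyano group. This rests on two pairs only: it does not show that the step would stay this small on any other core, including one of higher potency than those shown, and it gives no reason for the agreement.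

As far as these compounds go, both steps bring in trifluoromethyl, so other entering groups on the same aromatic carbons, such as chlorine, an amine or a carboxylic acid, remain open. Among the compounds shown here, also open is the effect of the ether and thioether links on their own, since no pair here isolates that difference, and that of a longer chain in the arm.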